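Ethyl to cyanomethyl: a step without a close precedent

The source may hold more compounds than are shown below. What is called first, only, known or untested is meant among the compounds shown, and "the series" means these compounds.

In an in vitro ADME assay on microsomes from liver (Mus musculus) for pharmacokinetics, read by LC-MS, with a stated time of 10 min, tested at 1 uM (a higher number here means faster removal of the compound, a lower number slower removal), compound 1 `CN1C[C@H](C(=O)Nc2ccc(Br)cc2)[C@@H](c2ccc(/C=C/C(=O)Nc3ccccc3N)cc2)C1` gives 16 mL/min/kg, compound 2 `CN1C[C@H](C(=O)Nc2ccc(F)c(Cl)c2)[C@@H](c2ccc(/C=C/C(=O)Nc3ccccc3N)cc2)C1` gives 34 mL/min/kg, and compound 3 `CCN1C[C@H](C(=O)Nc2ccc(Cl)cc2)[C@@H](c2ccc(/C=C/C(=O)Nc3ccccc3N)cc2)C1` gives 35 mL/min/kg. Compound 3 therefore sits level with compound 2 at the top of this small set, and clearly above compound 1.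

Compound 4 `N#CCN1C[C@H](C(=O)Nc2ccc(Cl)cc2)[C@@H](c2ccc(/C=C/C(=O)Nc3ccccc3N)cc2)C1` differs from compound 3 in one place: cyano in place of methyl on a saturated chain carbon bound to an amine nitrogen in a ring. Read one bond further out, this is ethyl to cyanomethyl.

Going by the values given here, only one measured step bears on this at all. That step, a 2.1-fold higher number from compound 1 to compound 2 (0.33 log units; beyond the scatter), is modest, and it sits on an amide-type nitrogen, away from the site that changes here. Among the compounds with values here, no measured pair shows what a change on the amine nitrogen does, so the data point to no direction, and in this assay no step beyond the scatter is expected. The estimated outcome is a 1.2-fold lower number from compound 3 to compound 4 (0.07 log units; within the scatter). For compound 4 the expected clearance is 30 mL/min/kg, with an estimated range from 14 mL/min/kg to 65 mL/min/kg.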

Compound 4, clearance: 51 mL/min/kg
Beside the measured number, compound 4's estimate is 1.7-fold (0.23 log units) below it; measured number inside the range.
By their numbers in this assay, from the lowest: compound 1; then compounds 2, 3 and 4 (each within the scatter of the next).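

In this assay, the ethyl to cyanomethyl change on the amine nitrogen in a ring gives a 1.5-fold higher number from compound 3 to compound 4 (0.16 log units; within the scatter) and is the only step shown at this position. Exchanging the methyl at the end of the ethyl group for a cyano group therefore produces no difference that can be told apart from ordinary repeat variation, so compound 3 and compound 4 count as level in this assay. No measurement shown bears on what lies behind this result.

As far as these compounds go, with a single pair isolating this position, it remains open whether any change on this nitrogen can shift clearance beyond the scatter. A carboxylic acid or a longer chain in place of the cyanomethyl group could test this, but the compounds shown do not indicate what either would do.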